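The source may hold more compounds than are shown below. What is called first, only, known or untested is meant among the compounds shown, and "the series" means these compounds.

Measured so far:
compound 1, `CC(C)CCOC(=O)Nc1nc(=O)n([C@@H]2O[C@H](C)[C@@H](O)[C@H]2O)cc1F`, 120 ug/mL in a functional assay on MCF7 cells (Homo sapiens) for cytotoxicity, read by MTT assay, with a stated time of 3 days; a higher number here means a weaker inhibitor, a lower number a stronger inhibitor;
compound 2, `CCC(C)COC(=O)Nc1nc(=O)n([C@@H]2O[C@H](C)[C@H]3OC(=O)O[C@H]32)cc1F`, 70 ug/mL;
compound 3, `C[C@H]1O[C@@H](n2cc(F)c(NC(=O)Oc3ccc([N+](=O)[O-])cc3)nc2=O)[C@@H]2OC(=O)O[C@@H]21`, 6 ug/mL.

Among the measured compounds shown here, compound 1 gives the highest of the three numbers; compound 2 sits within the scatter of it, compound 3 well beyond it, and compound 2 differs from compound 1 in more than one place, so no single step to compound 1 is available.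

Compound 4, `C[C@H]1O[C@@H](n2cc(F)c(NC(=O)Oc3ccc(Cl)cc3)nc2=O)[C@H](O)[C@@H]1O`, is not yet measured. It differs from compound 1 by 4-chlorophenyl in place of isopentyl on an oxygen next to a carbonyl group. For the measured compounds named here, one measured step bears on this: a 12-fold lower number from compound 2 to compound 3 (1.07 log units; beyond the scatter), where an aromatic ring likewise replaced a branched chain on the oxygen next to the carbonyl group. The aromatic ring that enters in compound 4 carries chlorine rather than the nitro group of compound 3, and the core of compound 1 is not that of compound 2, so the step is expected to be somewhat smaller but in the same direction: an expected 8.0-fold lower number from compound 1 to compound 4 (0.90 log units; beyond the scatter). For compound 4 the estimate in this assay is therefore 15 ug/mL, within 5 ug/mL to 45 ug/mL.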

Compound 4, half-maximal inhibitory concentration: 100 ug/mL
Beside the measured number, compound 4's estimate is 6.7-fold (0.82 log units) below it; measured number above the stated range.
By their numbers in this assay, from the lowest: compound 3; then compounds 2, 4 and 1 (each within the scatter of the next).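

In this assay, on the core of compound 1, 4-chlorophenyl in place of isopentyl on an oxygen next to a carbonyl group gives a 1.2-fold lower number from compound 1 to compound 4 (0.08 log units; within the scatter), so this pair shows no separation. Among the compounds shown here, an aromatic ring at this position therefore does not by itself go with a lower number: the only step there beyond the scatter is a 12-fold lower number from compound 2 to compound 3 (1.07 log units; beyond the scatter), which brings in 4-nitrophenyl on a different core. No measurement at hand accounts for the contrast between these two steps.

Still open, as far as these compounds go, is whether that contrast follows the nitro group, the chlorine or the core: each of these aromatic groups appears on one core only. Also open, from the compounds shown here alone, is how a longer chain or a methoxyphenyl group at this position would read on either core.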